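The source may hold more compounds than are shown below. What is called first, only, known or untested is meant among the compounds shown, and "the series" means these compounds.

Compound 1 `FC(F)(F)c1ccc(CN2CCN(Cc3cc(-c4ccc(OCc5ccccc5)cc4)on3)CC2)cc1` gives 1700 nM in a functional assay on Huh-7 cells (Homo sapiens) for antiproliferative activity, read by sulforhodamine B assay, with a stated time of 72 h; on this read-out higher numbers stand for weaker inhibition and lower numbers for stronger inhibition.
Compound 2 `COc1ccc(COc2ccc(-c3cc(CN4CCN(Cc5ccc(C(F)(F)F)cc5)CC4)no3)cc2)cc1` gives 3200 nM in this assay.
Compound 3 `N#Cc1cccc(COc2ccc(-c3cc(CN4CCN(c5ccc(F)cc5)CC4)no3)cc2)c1` gives 1500 nM in this assay.

Compound 3 holds the lowest of the three numbers, but its gap to compound 1 lies within the scatter, so the two cannot be told apart; only compound 2 stands beyond it. Going by the values given here, the one measured step, a 1.9-fold higher number from compound 1 to compound 2 (0.27 log units; within the scatter), concerns a substituent on an aromatic carbon far from the ring nitrogen and so does not bear on the change now in question. Compound 4 `N#Cc1cccc(COc2ccc(-c3cc(CN4CCN(C(=O)C5CCCO5)CC4)no3)cc2)c1` differs from compound 3 in one place: (oxolan-2-yl)carbonyl in place of 4-fluorophenyl on an amine nitrogen in a ring. Among the compounds with values here, no measured pair touches the group on that ring nitrogen, and compounds 1 and 3 differ from each other in two places, so their values only show that an aryl and a benzyl group there both give numbers close together. With nothing to anchor the amide, compound 4 is expected to give a somewhat higher number, a 2.3-fold higher number from compound 3 to compound 4 (0.37 log units; beyond the scatter), with a wide range. The estimate for compound 4 in this assay is 3500 nM, between 900 nM and 14000 nM.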

Compound 4, half-maximal inhibitory concentration: 2200 nM
Compound 4: the middle estimate sits 1.6-fold (0.20 log units) above what was measured; the measured number falls inside the stated range.
By their numbers in this assay, from the lowest: compounds 3, 1, 4 and 2 (each within the scatter of the next, the first and the last beyond it).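

In this assay, going by these compounds alone, (oxolan-2-yl)carbonyl in place of 4-fluorophenyl on an amine nitrogen in a ring gives a 1.5-fold higher number from compound 3 to compound 4 (0.17 log units; within the scatter) and is the first measured step at this nitrogen. In this single pair, a carbonyl-linked, non-aromatic ring with hydrogen-bond acceptors replaces an aromatic ring without any, and the change in the number stays within the scatter. No supporting measurement is available to explain this result.

On these data alone, it remains open whether an acetyl group, a bare amine hydrogen or a longer chain ending in a carboxylic acid would also leave the number within the scatter at this nitrogen. As far as these compounds go, it is also open whether the same change would give a similar step on the core of compound 1 or compound 2.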